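A few compounds are considered here, and "the series" means these few. Any claim that something is new, unique, unknown or untested is made for them only; others in the source may bear on it.

Compound 3 `CCn1c(SCc2cc([N+](=O)[O-])ccc2OC)nc2cc(NC(=O)NC(C)(C)C)ccc21` is the compound with the lowest number among the three measured in an assay on isolated protein for inhibition of Gonadotropin-releasing hormone receptor (Homo sapiens); a lower number here means a stronger inhibitor, a higher number a weaker inhibitor. Compound 3 gives 42 nM. The nearest of the others is compound 2 `COc1ccc(C(C)=O)cc1CSc1nc2cc(NC(=O)C3CC3)ccc2n1C(C)C`, which in this assay gives 260 nM; the furthest is compound 1 `COc1ccccc1CSc1nc2cc(NC(=O)C3CC3)ccc2n1C(C)C`, which in this assay gives 2100 nM. Compound 3 differs from both in more than one place, so only the two values themselves can be set side by side. Among the measured compounds shown here, the single one-place step among the measured compounds is an 8.1-fold lower number from compound 1 to compound 2 (0.91 log units; beyond the scatter), acetyl in place of hydrogen on an aromatic carbon.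

Compound 4 `COc1ccc([N+](=O)[O-])cc1CSc1nc2cc(NC(=O)NC(C)(C)C)ccc2n1Cc1ccccc1` is compound 3 with one change: phenyl in place of methyl on a saturated chain carbon bound to an aromatic nitrogen, or, cut one bond further out, ethyl to benzyl. For the measured compounds named here, no measured step touches the group on the aromatic nitrogen; the step from compound 1 to compound 2 concerns a different part of the shared core and gives no direct guide. For compound 4 the expectation is therefore a step of uncertain direction, most likely not far beyond the scatter, written as a 1.4-fold higher number from compound 3 to compound 4 (0.15 log units; within the scatter). Compound 4 is estimated in this assay at 60 nM, with a range from 15 nM to 250 nM.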

Compound 4, half-maximal inhibitory concentration: 28 nM
Beside the measured number, compound 4's estimate is 2.1-fold (0.33 log units) above it; low and high end bracket the measured number.
By their numbers in this assay, from the lowest: compounds 4 and 3 (each within the scatter of the next); then compound 2; then compound 1.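

Among the compounds shown here, the step from ethyl to benzyl gives the first reading at the group on the aromatic nitrogen: in this assay there is a 1.5-fold lower number from compound 3 to compound 4 (0.18 log units; within the scatter) with this change. A phenyl, with its six-membered aromatic ring of carbon only, can thus take the place of methyl on the saturated chain carbon bound to the aromatic nitrogen with no change that stands out from the scatter, so the larger group leaves the number in the same range and compound 4 stays level with compound 3. Nothing in the available data offers an explanation for this outcome.

The compounds shown leave open whether this position would accept more than a plain benzyl, such as a benzyl ring carrying an amine or a carboxylic acid, or a longer chain ending in phenyl. For the compounds shown here, they also leave open whether benzyl would read the same way on compound 2, with its acetyl group and cyclopropyl amide, since the only other one-place step concerns a different part of the shared core.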